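The compounds below may be only part of what the source reports. "The series", "measured", "known", "first", "only" and "open" are said of these compounds alone.

Of the compounds shown here, two have been tested in a functional assay on HepG2 cells (Homo sapiens) for cytotoxicity, read by MTT assay; on this read-out higher numbers stand for weaker inhibition and lower numbers for stronger inhibition. Compound 1 `COc1ccc(-c2c(C)oc3cc(OC)c(O)cc23)cc1O` is reported in this assay as "not active" (no number reported), with no number attached. Compound 2 `COc1ccc([C@H]2Oc3cc(OC)c(OC)cc3[C@@H]2C)cc1O` shares the substitution pattern of compound 1 on a different core. In this assay compound 2 gives > 19.4 ug/mL, which is a limit of the assay rather than a measured number. For the measured compounds named here, compound 2 therefore sits at the limit of > 19.4 ug/mL in this assay, at which 1 of the 2 values shown sits, and no entry of the series so far carries a single number in this assay. Of the gap between compound 1 and compound 2 nothing can be said, as neither value is a number.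

Compound 3 `COc1ccc([C@H]2Oc3cc(OC)c(O)cc3[C@@H]2C)cc1O` is the next entry and has not yet been measured. It differs from compound 2 by hydrogen in place of methyl on an oxygen on an aromatic ring. Going by the values given here, no measured step between compounds is available to scale this change. The step that the limit leaves unreadable from compound 2 to compound 3 is expected to be none beyond the scatter. Compound 3 is accordingly estimated at 25 ug/mL, within a range of 12 ug/mL to 60 ug/mL, with a fair chance that this assay again reports only a limit.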

Compound 3, half-maximal inhibitory concentration: 7.7 ug/mL
For compound 3 the middle estimate is 3.2-fold (0.51 log units) above the measured one, outside the stated range (below it).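

In this assay, for the compounds shown here, hydrogen in place of methyl on an oxygen on an aromatic ring gives an at least 2.5-fold lower number from compound 2 to compound 3 (0.40 log units; beyond the scatter), the first readable step and the first sign that the read-out responds to a change at this place. With this methoxy to hydroxy change, compound 3 becomes the first entry with a single number, 7.7 ug/mL, giving the series a measured reference point in this assay. The size of the step is only a lower bound, because compound 2 stands at a limit of the assay rather than at a number: the limit of > 19.4 ug/mL in this assay, at which 1 of the 3 values shown sits.

The compounds shown leave open whether the hydroxy itself matters or only the loss of the methyl, which an ethoxy, an amine or a fluorine at the same place would help to separate. Steps to compound 1 cannot be read, as it has no number in this assay, so whether this change would give a similar result on the core of compound 1 also remains open.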